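This account rests on a few compounds, and the source may have more. Where it says the series, first, only, none or still open, it means among the compounds named here.

Measured so far:
Compound 1, `CC(C)C[C@]1(O)NC(=O)[C@]2(OC(Cc3ccccc3)=CC2=O)[C@H]1O`, gives > 50000 nM in a functional assay on Jurkat cells (Homo sapiens) for cytotoxicity, read by WST assay, with a stated time of 48 h; a lower number here means a stronger inhibitor, a higher number a weaker inhibitor; this value is a limit of the assay, not a number.
Compound 2, `Cc1cc2c(c(=O)[nH]1)OC(C(=O)CC(C)C)O2`, gives > 50000 nM in this assay; this value is likewise only a limit.

Compound 1 therefore stands at the limit of > 50000 nM in this assay, at which 2 of the 2 values shown sit. Both measured values stop at the same point, so nothing shown separates compound 1 from compound 2, and no step between measured compounds can be counted. The unmeasured compound 3, `CC1=CC(=O)[C@]2(O1)C(=O)N[C@@](O)(CC(C)C)[C@@H]2O`, differs from compound 1 by hydrogen in place of phenyl on a saturated chain carbon bound to a double-bonded ring carbon. For the measured compounds named here, no measured step speaks to this change, and the measured values give no room for a further loss to show itself. In this assay the step of a number no higher from compound 1 to compound 3 (the limit leaves the size open) is expected to be none beyond the scatter. For compound 3 in this assay the value is estimated at 50000 nM, with a range from 20000 nM to 200000 nM.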

Compound 3, half-maximal inhibitory concentration: > 50000 nM
Compound 3 ended at the assay's limit; the forecaster's own chance of this, stated with the estimate: 85%; the middle value sits exactly at the limit.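

No step can be read between compound 1 and compound 3, as both stop at the limit of this assay. The compounds shown leave open whether hydrogen in place of phenyl makes any difference in this assay, and which change would bring a value inside that limit.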